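Swapping an Aryl Ether for a Cyanobenzyl Group

This account rests on a few compounds, and the source may have more. Where it says the series, first, only, none or still open, it means among the compounds named here.

Measured compounds:
- Compound 1, `COc1cccc(CNCCCNc2ccnc3cc(Oc4ccc(Cl)cc4)ccc23)c1O`: 317 10^-6 cm/s
- Compound 2, `COc1ccc(F)cc1CNCCCNc1ccnc2cc(CCc3ccccc3)ccc12`: 23 10^-6 cm/s
- Compound 3, `COc1cccc(CNCCCNc2ccnc3cc(-c4cc(C(F)(F)F)cc(C(F)(F)F)c4)ccc23)c1O`: 237 10^-6 cm/s

These three compounds share a core and were all tested in an ADME assay for permeability, using PAMPA, with a stated time of 30 min, at pH 7.4; a lower number here means that the compound crosses the layer more slowly, a higher number that the compound crosses the layer faster. Compound 1 gives 317 10^-6 cm/s, the highest of the three numbers. Compound 3 lies within the usual scatter of compound 1, so the two cannot be told apart on these numbers. Compound 2, which gives 23 10^-6 cm/s, is clearly lower than compound 1, beyond the scatter.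

The next compound to be measured is compound 4, `COc1cccc(CNCCCNc2ccnc3cc(Cc4ccc(C#N)cc4)ccc23)c1O`. It differs from compound 1 in one place: 4-cyanobenzyl in place of 4-chlorophenoxy on an aromatic carbon. Going by the values given here, no step between two measured compounds matches this change, so the expectation rests only on how compound 1 itself behaves.

Since compound 1 already gives a high number in this assay, and the change keeps the same count of hydrogen-bond donors and acceptors, a modest fall is expected, likely no larger than the scatter. The step from compound 1 to compound 4 is expected to be a 1.6-fold lower number from compound 1 to compound 4 (0.20 log units; within the scatter). For compound 4 the expected value is 200 10^-6 cm/s, in a range from 90 10^-6 cm/s to 380 10^-6 cm/s.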

Compound 4, apparent permeability: 23 10^-6 cm/s
Compound 4: middle estimate off by 8.7-fold (0.94 log units), on the high side, outside the stated range (below it).
By their numbers in this assay, from the lowest: compounds 2 and 4 (each within the scatter of the next); then compounds 3 and 1 (each within the scatter of the next).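

In this assay, putting 4-cyanobenzyl in place of 4-chlorophenoxy gives a 14-fold lower number from compound 1 to compound 4 (1.14 log units; beyond the scatter), a large step. Going by these compounds alone, the three earlier compounds included no pair differing in only one place, so they could not show what a single change on this aromatic carbon of the shared core does to the read-out; this step shows that such a change alone can move the number well beyond the scatter, even though both groups count one six-membered aromatic ring of carbon only, no hydrogen-bond donors and one hydrogen-bond acceptor. Nothing measured here explains the fall.

This single step removes the oxygen and the chlorine and brings in the nitrile all at once, leaving open which of these parts goes with the lower number; a 4-chlorobenzyl or a 4-cyanophenoxy group at the same place would separate them. Also open, going by these compounds, is how far the number would move with a quite different group on this carbon, such as an amine or a carboxylic acid.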